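A few compounds are considered here, and "the series" means these few. Any claim that something is new, unique, unknown or untested is made for them only; others in the source may bear on it.

Measured compounds:
Compound 1, `Cc1cn([C@H]2C[C@H](O)[C@](CO)(Sc3ccccc3)S2)c(=O)[nH]c1=O`. In an ADME assay on MT4 cells (Homo sapiens) for cytotoxicity, read by MTT assay, with a stated time of 4 days (on this read-out higher numbers stand for lower toxicity in this test and lower numbers for higher toxicity in this test), compound 1 gives > 100000 nM, which is a limit of the assay and not a number.
Compound 2, `Cc1cn([C@H]2C[C@H](O)[C@](CO)(N=[N+]=[N-])S2)c(=O)[nH]c1=O`. In this assay compound 2 gives 40000 nM.

Compound 2 therefore carries the only number in this small set; the other entry is a limit, as shown by the limit of > 100000 nM in this assay, at which 1 of the 2 values shown sits. Going by the values given here, the single measured step is an at least 2.5-fold lower number from compound 1 to compound 2 (0.39 log units; beyond the scatter), and it lies beyond the scatter.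

Compound 3, `CO[C@]1(CO)S[C@@H](n2cc(C)c(=O)[nH]c2=O)C[C@@H]1O`, differs from compound 2 by methoxy in place of azido on a saturated ring carbon. Among the compounds with values here, the one measured step bears on it only loosely: it changed the same ring carbon, and swapping a large phenylsulfanyl for a small azido lowered the number, meaning greater toxicity in this assay. Methoxy is a third small group at that carbon, and no measured step covers it directly, so the expectation for this assay is a step of no more than modest size, most likely back toward a higher number, possibly none beyond the scatter. The expected step is a 2.0-fold higher number from compound 2 to compound 3 (0.30 log units; within the scatter). Compound 3 is estimated at 80000 nM, within a range from 25000 nM to 300000 nM.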

Compound 3, half-maximal cytotoxic concentration: > 100000 nM
Compound 3: only a limit was reported; the forecaster's own chance of this, stated with the estimate: 45%; at least 1.2-fold (0.09 log units) between middle value and limit.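

In this assay, methoxy in place of azido on this saturated ring carbon, next to the ring sulfur, gives an at least 2.5-fold higher number from compound 2 to compound 3 (0.39 log units; beyond the scatter), so the lower number of compound 2 does not follow from simply replacing phenylsulfanyl with any group of few heavy atoms. Compound 1 and compound 3 carry very different groups at this carbon, phenylsulfanyl and methoxy, yet among the three compounds only the azido compound, compound 2, gives an actual number, and the other two stop at the same limit: the limit of > 100000 nM in this assay, at which 2 of the 3 values shown sit. Both of those entries are limits and not numbers, so the step between compound 1 and compound 3 cannot be read, and the data do not order these two compounds.

Going by these compounds, it remains open whether azido is unusual at this carbon or whether other groups, such as an amine, would also bring the number down in this assay. A longer chain on the oxygen, such as ethoxy, would show whether the result for methoxy carries over to a close relative.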